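The source may hold more compounds than are shown below. What is called first, only, known or untested is meant among the compounds shown, and "the series" means these compounds.

The measured compounds in a functional assay on A549 cells (Homo sapiens) for inhibition, read by MTT assay, with a stated time of 24 h; a lower number here means a stronger inhibitor, a higher number a weaker inhibitor:

Compound 1, `CCOC(=O)C1=Cc2ccccc2OC1(OCc1cn(CC(=O)Nc2ccc(C)cc2)nn1)C(F)(F)F`, gives 54300 nM.
Compound 2, `CCOC(=O)C1=Cc2ccccc2OC1(OCc1cn(CC(=O)Nc2ccccc2Br)nn1)C(F)(F)F`, reaches only the limit of this assay, > 150000 nM.
Compound 3, `CCOC(=O)C1=Cc2ccccc2OC1(OCc1cn(CC(=O)Nc2ccccc2F)nn1)C(F)(F)F`, gives 50100 nM.

Compound 3 holds the lowest of the two numbers shown, but its nearest neighbour, compound 1, is separated from it only by a 1.1-fold lower number from compound 1 to compound 3 (0.03 log units; within the scatter), a gap within the scatter. Compound 2 sits at the limit of > 150000 nM in this assay, at which 1 of the 3 values shown sits. The two steps that move beyond the scatter, an at least 2.7-fold higher number from compound 1 to compound 2 (0.44 log units; beyond the scatter) and an at least 2.9-fold lower number from compound 2 to compound 3 (0.47 log units; beyond the scatter), both come from exchanging the aryl group on the amide-type nitrogen.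

Compound 4, `CCOC(=O)C1=Cc2ccccc2OC1(OCc1cn(-c2ccc(F)c(Cl)c2)nn1)C(F)(F)F`, differs from compound 3 by 3-chloro-4-fluorophenyl in place of ((2-fluorophenyl)carbamoyl)methyl on an aromatic nitrogen. For the measured compounds named here, no measured step bears directly on this change: every step so far kept the ((aryl)carbamoyl)methyl arm and varied only its aryl group, whereas here the whole arm is replaced by a halogenated phenyl set directly on the ring nitrogen. The measured steps show that changes at this end of the molecule can move the number beyond the scatter in either direction, but give no direction for this one. The account therefore expects a step of a 1.1-fold higher number from compound 3 to compound 4 (0.04 log units; within the scatter), and estimates compound 4 at 55000 nM, in the range 15000 nM to 150000 nM.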

Compound 4, half-maximal inhibitory concentration: 26300 nM
Compound 4: the middle estimate sits 2.1-fold (0.32 log units) above what was measured, within the range that was stated.
By their numbers in this assay, from the lowest: compounds 4, 3 and 1 (each within the scatter of the next, the first and the last beyond it). At a limit, above all of these: compound 2.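

Compound 4 shows that the whole ((aryl)carbamoyl)methyl arm, with its amide hydrogen and carbonyl, can be replaced on the aromatic nitrogen by a directly attached 3-chloro-4-fluorophenyl without loss in this assay: the change gives a 1.9-fold lower number from compound 3 to compound 4 (0.28 log units; within the scatter), so the number holds at the level of compound 3 even though the arm's hydrogen-bond donor is gone. Measured against the arm that carries 4-methylphenyl, the same kind of replacement gives a 2.1-fold lower number from compound 1 to compound 4 (0.31 log units; beyond the scatter), a modest gain that the changes of aryl group within the arm had not produced for compound 3 over compound 1. Against the arm that carries 2-bromophenyl it gives an at least 5.7-fold lower number from compound 2 to compound 4 (0.75 log units; beyond the scatter), a step that is only a bound, as compound 2 has a limit rather than a number: the limit of > 150000 nM in this assay, at which 1 of the 4 values shown sits.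

With a single directly attached aryl group in view, the compounds shown do not separate the loss of the arm from the effect of the chloro and fluoro substituents on the new ring. A plain phenyl or a benzyl on the same nitrogen would bear on that question, and an amine or a carboxylic acid on the new ring remains an open case.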